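Replacing butoxy with chloro on the shared core

A few compounds are considered here, and "the series" means these few. Any claim that something is new, unique, unknown or untested is made for them only; others in the source may bear on it.

In a functional assay on HL-60 cells (Homo sapiens) for cytotoxicity, read by WST assay, with a stated time of 48 h (a higher number here means that more compound is needed for the effect, a lower number that less compound is needed), compound 1 `O=C1OC[C@H](Cc2ccccc2)[C@H]1Cc1cccc(O)c1` gives > 100000 nM, which is a limit of the assay and not a number. Compound 2 `COCOc1ccc(C[C@H]2C(=O)OC[C@@H]2Cc2ccccc2)cc1` gives 71000 nM. Compound 3 `CCCCOc1ccc(C[C@H]2C(=O)OC[C@@H]2Cc2ccccc2)cc1` gives 23000 nM, the lower of the two actual numbers in the series.

Compound 4 `O=C1OC[C@H](Cc2ccccc2)[C@H]1Cc1ccc(Cl)cc1` is the next case. The change is chloro in place of butoxy on an aromatic carbon.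

Going by the values given here, the one measured step that bears on this change is a 3.1-fold lower number from compound 2 to compound 3 (0.49 log units; beyond the scatter), made in the same substituent. It is modest. With the butoxy chain gone, the lower number seen in that step is not expected to carry over to compound 4, so a modest move towards a higher number in this assay is expected.

The expected change is a 2.0-fold higher number from compound 3 to compound 4 (0.29 log units; within the scatter).

For compound 4, the estimated value is 45000 nM, with an expected range of 15000 nM to 100000 nM.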

Compound 4, half-maximal effective concentration: 36000 nM
The estimate for compound 4 lay 1.3-fold (0.10 log units) above the measured number, and the stated range covers the measured number.
By their numbers in this assay, from the lowest: compounds 3, 4 and 2 (each within the scatter of the next, the first and the last beyond it). At a limit, above all of these: compound 1.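

In this assay, this aromatic carbon takes chloro, a single heavy atom, without a step beyond the scatter from either oxygen-linked chain: a 1.6-fold higher number from compound 3 to compound 4 (0.19 log units; within the scatter), and a 2.0-fold lower number from compound 2 to compound 4 (0.29 log units; within the scatter). The butoxy chain is therefore not required for a number in this range, and the gap between compound 2 and compound 3 does not by itself set a trend with chain size, since compound 4 lies within the scatter of both. Setting 4-chlorophenyl in place of 3-hydroxyphenyl gives an at least 2.7-fold lower number from compound 1 to compound 4 (0.44 log units; beyond the scatter), but this step has a limit of the assay and not a number at its upper end: the limit of > 100000 nM in this assay, at which 1 of the 4 values shown sits.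

Still open, going by these compounds, is how an amine or a carboxylic acid on this aromatic carbon would read in this assay. On these data alone, a chain longer than butoxy is also open.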